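A few compounds are considered here, and "the series" means these few. Any claim that something is new, unique, unknown or untested is made for them only; others in the source may bear on it.

Of the compounds shown here, three have so far been read in a functional assay on SK-MEL-28 cells (Homo sapiens) for inhibition, read by colorimetric assay and MTT assay, with a stated time of 72 h; on this read-out lower numbers stand for stronger inhibition and higher numbers for weaker inhibition. In this assay, for the measured compounds named here, compound 1 `C=CCCCCOc1ccc(C)cc1-c1cnc(OCCC=C)n1C` gives 83000 nM, the only actual number among them. For compound 2 `COc1ccccc1-c1cnc(OC)n1C` the result is a limit, > 100000 nM, and not a number. For compound 3 `C=CCCCCOc1ncc(I)n1C` the result is likewise a limit, > 100000 nM. Compound 3 therefore stands at the limit of > 100000 nM in this assay, at which 2 of the 3 values shown sit, and its true value is not known.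

The next compound, compound 4 `C=CCCCCOc1nccn1C`, differs from compound 3 in one place: hydrogen in place of iodo on an aromatic carbon. This is hydrogen in place of iodo on an aromatic carbon, and the rest of the structure stays the same. Going by the values given here, no pair of measured compounds shows this exchange, so the data give no direct measure of its size in this assay. The expectation therefore starts from compound 3, whose limit is > 100000 nM. No change beyond the scatter is expected, in either direction, and the estimated step that the limit leaves unreadable from compound 3 to compound 4 is correspondingly small. It is also quite possible that this assay will again report only a limit. For compound 4 the estimated value is 120000 nM, with an expected range of 70000 nM to 200000 nM.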

Compound 4, half-maximal inhibitory concentration: > 100000 nM
Compound 4: a limit, no number; the forecaster's own chance of this, stated with the estimate: 80%; the middle value lies beyond the limit too.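

In this assay compound 3 and compound 4 both end in a limit and not a number, so no step between them can be read: the limit of > 100000 nM in this assay, at which 3 of the 4 values shown sit.

The compounds shown leave open whether hydrogen in place of iodo on an aromatic carbon changes inhibition at all, and in which direction.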